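From compound 2 to a 4-chloropyridin-2-yl analogue

The source may report more compounds than this note shows. Statements on the series, on what has been measured and on what is new or still open speak of the compounds shown alone.

In a functional assay on HOS-TE85 cells (Homo sapiens) for inhibition, read by CCK-8 assay, with a stated time of 72 h (on this read-out lower numbers stand for stronger inhibition and higher numbers for weaker inhibition), compound 1 (`O=C(NCCCCn1cccn1)c1cccc(C2SCC(=O)N2c2cc(Br)ccn2)c1`) gives 105 nM and compound 2 (`CCOC(=O)c1sc(N2C(=O)CSC2c2cccc(C(=O)NCCCCn3cccn3)c2)nc1C`) gives 430 nM as the higher of the two numbers. Among the measured compounds shown here, the only measured step, a 4.1-fold higher number from compound 1 to compound 2 (0.61 log units; beyond the scatter) and beyond the scatter, places 5-(ethoxycarbonyl)-4-methyl-1,3-thiazol-2-yl where compound 1 has 4-bromopyridin-2-yl on an amide-type nitrogen in a ring.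

Compound 3 (`O=C(NCCCCn1cccn1)c1cccc(C2SCC(=O)N2c2cc(Cl)ccn2)c1`) has not yet been measured. It carries 4-chloropyridin-2-yl in place of 5-(ethoxycarbonyl)-4-methyl-1,3-thiazol-2-yl at that nitrogen (4-chloropyridin-2-yl in place of 5-(ethoxycarbonyl)-4-methyl-1,3-thiazol-2-yl on an amide-type nitrogen in a ring). This change nearly reverses the measured step, with chlorine standing where compound 1 has bromine. For the measured compounds named here, no measured step isolates that halogen exchange, so the reversal can only be taken as approximate. A move to a lower number in this assay is therefore expected, of roughly the size seen between compound 1 and compound 2, and probably slightly smaller.

The estimated change is a 3.3-fold lower number from compound 2 to compound 3 (0.52 log units; beyond the scatter) in this account. For compound 3 the estimated value is 130 nM with an expected range from 50 nM to 340 nM in this assay once it is measured.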

Compound 3, half-maximal inhibitory concentration: 36.4 nM
The estimate for compound 3 lay 3.6-fold (0.55 log units) above the measured number, and the stated range ends above it.
By their numbers in this assay, from the lowest: compound 3; then compound 1; then compound 2.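

In this assay, the change at this amide-type nitrogen proves larger than the earlier step suggested: a 12-fold lower number from compound 2 to compound 3 (1.07 log units; beyond the scatter), against a 4.1-fold higher number from compound 1 to compound 2 (0.61 log units; beyond the scatter) in the opposite direction. The halogen on the pyridin-2-yl group also matters, with a 2.9-fold lower number from compound 1 to compound 3 (0.46 log units; beyond the scatter) for chloro in place of bromo on an aromatic carbon, a modest step but beyond the scatter, so the read-out at this position responds to the exchange of a single halogen as well as to the exchange of the whole ring, and compound 3 ends up the strongest of the three. Nothing available accounts for either step, so the preference for chloro over bromo and for the pyridinyl groups over the thiazolyl group stands as an observation only.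

Among the compounds shown, the thiazolyl group carries its ethoxycarbonyl and methyl groups together, so the large step cannot be divided between the ring and those groups. On these data alone, it also remains open whether a 4-fluoropyridin-2-yl, 4-methoxypyridin-2-yl or plain pyridin-2-yl group on the same nitrogen would extend the trend from bromo to chloro, and whether the order would hold with a shorter chain on the amide of the shared core.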